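Swapping an aryl for a saturated ring at the side chain

The source may report more compounds than this note shows. Statements on the series, on what has been measured and on what is new or still open speak of the compounds shown alone.

Three compounds share one core and differ only in the group on the aromatic nitrogen. Compound 1 `CNC(=O)c1cc(C(=O)NC2CC2)cn(CC2CCOCC2)c1=O` gives 1.5 in a physicochemical assay for lipophilicity, at pH 7.4; a higher number here means a more lipophilic compound, a lower number a more polar compound. Compound 2 `CNC(=O)c1cc(C(=O)NC2CC2)cn([C@H](C)c2ccccc2)c1=O` gives 3.4, and compound 3 `CNC(=O)c1cc(C(=O)NC2CC2)cn(Cc2cccc(C#N)c2)c1=O` gives 2.6. Among these three numbers compound 3 stands second highest: compound 2 lies a number 1.90 log units higher from compound 1 to compound 2 (beyond the scatter) above compound 1, while compound 3 lies a number 1.10 log units higher from compound 1 to compound 3 (beyond the scatter) above compound 1 and below compound 2.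

Compound 4 `CNC(=O)c1cc(C(=O)NC2CC2)cn(CC2CCCCC2)c1=O` has not yet been measured. It differs from compound 3 in one place: cyclohexyl in place of 3-cyanophenyl on a saturated chain carbon bound to an aromatic nitrogen. The two measured steps both change the group at this same place, and both moved the number upward by a large amount, a number 1.90 log units higher from compound 1 to compound 2 (beyond the scatter) and a number 1.10 log units higher from compound 1 to compound 3 (beyond the scatter). A saturated ring of carbon only entering for a cyanophenyl is expected to shift the number further in that same direction, though by less than those steps. Compound 4 is therefore estimated at 3.3, between 2.8 and 3.8, an expected step of a number 0.70 log units higher from compound 3 to compound 4 (beyond the scatter).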

Compound 4, distribution coefficient: 4
The estimate for compound 4 lay 0.70 log units below the measured number; the measured number lies above the stated range.
By their numbers in this assay, from the lowest: compound 1; then compound 3; then compound 2; then compound 4.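

In this assay, cyclohexyl on the saturated chain carbon bound to an aromatic nitrogen gives a number 1.40 log units higher from compound 3 to compound 4 (beyond the scatter) and a number 2.50 log units higher from compound 1 to compound 4 (beyond the scatter), so the all-carbon saturated ring stands well clear of both the 3-cyanophenyl and the oxan-4-yl. Cyclohexylmethyl also passes 1-phenylethyl on the aromatic nitrogen, with a number 0.60 log units higher from compound 2 to compound 4 (beyond the scatter), which makes compound 4 the highest of the four and shows that an aromatic ring is not needed here for a high number. No measurement bears on why the number moves this way.

Still open, on these data alone, is where a plain phenyl ring without the nitrile would fall on this chain carbon, a comparison that would separate the change of ring from the loss of the nitrile. A piperidine ring, a saturated ring holding an amine, is also untested among the compounds shown.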